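Replacing the butyl chain with a 2-fluorophenyl ring

The compounds below may be only part of what the source reports. "The series", "measured", "known", "first", "only" and "open" are said of these compounds alone.

Of the compounds shown here, three share the same core and have been tested in a functional assay on Huh-7 cells (Homo sapiens) for inhibition, read by sulforhodamine B assay; on this read-out lower numbers stand for stronger inhibition and higher numbers for weaker inhibition. Compound 1 `C#CC(=O)N1C(c2ccc(C#N)cc2)SC[C@@H]1C(=O)OCC`, which carries a substituted phenyl ring, gives 2600 nM. Compound 2 `C#CC(=O)N1C(CC(C)CC(C)(C)C)SC[C@@H]1C(=O)OCC` gives 1600 nM, and compound 3 `C#CC(=O)N1C(CCCC)SC[C@@H]1C(=O)OCC` gives 500 nM. Among the compounds with values here, compound 3 therefore stands lowest of the three, with a 3.2-fold lower number from compound 2 to compound 3 (0.51 log units; beyond the scatter) the only single-point step among the measured compounds, and compound 1 further away still.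

Compound 4 `C#CC(=O)N1C(c2ccccc2F)SC[C@@H]1C(=O)OCC` differs from compound 3 by 2-fluorophenyl in place of butyl on a saturated ring carbon. Within the data shown here, no measured step covers this exact exchange; the nearest evidence is that compound 1, the only other member with an aromatic group on that ring carbon, gives a higher number than compound 3, and that the branched chain of compound 2 also sits higher. On that basis a moderate rise is expected, of about a 3.0-fold higher number from compound 3 to compound 4 (0.48 log units; beyond the scatter), so compound 4 is estimated at 1500 nM, within a range of 500 nM to 4500 nM.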

Compound 4, half-maximal inhibitory concentration: 1700 nM
Beside the measured number, compound 4's estimate is 1.1-fold (0.05 log units) below it; the range from low to high includes it.
By their numbers in this assay, from the lowest: compound 3; then compounds 2, 4 and 1 (each within the scatter of the next).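

In this assay, within the data shown here, the exchange of butyl for 2-fluorophenyl on the saturated ring carbon gives a 3.4-fold higher number from compound 3 to compound 4 (0.53 log units; beyond the scatter) and provides the first direct step at this position from a straight chain to an aromatic ring. Compound 4 joins compounds 2 and 1 in a group where each lies within the scatter of the next, so only compound 3 stands clear of the others, and the branched chain and the two substituted phenyl rings are not told apart here. Nothing at hand gives a measured reason for this step.

The compounds shown leave open how an unsubstituted phenyl ring would read, so the share of the fluorine cannot be separated from that of the ring. They also leave open whether a longer straight chain such as hexyl, or a butyl chain ending in an amine, would read near compound 3.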